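The source may hold more compounds than are shown below. What is called first, only, known or untested is meant among the compounds shown, and "the series" means these compounds.

Measured so far in a functional assay on Ishikawa cells (Homo sapiens) for antiproliferative activity, read by CCK-8 assay, with a stated time of 48 h; on this read-out higher numbers stand for weaker inhibition and lower numbers for stronger inhibition:
- compound 1 `C=CC(=O)NCCOc1ccc(Oc2c(-c3ccc(F)cc3)sc3cc(O)ccc23)cc1`: in this assay compound 1 gives only a limit, > 25000 nM.
- compound 2 `CN(C)C(=O)/C=C/CNCCOc1ccc(Oc2c(-c3ccc(F)cc3)sc3cc(O)ccc23)cc1`: in this assay compound 2 gives 11900 nM.
- compound 3 `O=C(/C=C/CN1CC(Oc2ccc(Oc3c(-c4ccc(F)cc4)sc4cc(O)ccc34)cc2)C1)N1CCCC1`: in this assay compound 3 gives 9150 nM.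

Compound 1 therefore stands at the edge of what this assay reports, a limit rather than a number, as the limit of > 25000 nM in this assay, at which 1 of the 3 values shown sits, records. Compound 4 `C=C(C)C(=O)N1CC(Oc2ccc(Oc3c(-c4ccc(F)cc4)sc4cc(O)ccc34)cc2)C1` differs from it by 1-((1-methylethenyl)carbonyl)azetidin-3-yl in place of 2-((vinylcarbonyl)amino)ethyl on an oxygen on an aromatic ring. Of the measured steps only an at least 2.1-fold lower number from compound 1 to compound 2 (0.32 log units; beyond the scatter) changes the same side chain, and it moved the number beyond the scatter. Compound 3, which also carries an azetidine ring on that oxygen, gives a number rather than a limit. The step to compound 4 keeps a small unsaturated carbonyl group and adds the ring, so a modest drop is expected, an at least 1.6-fold lower number from compound 1 to compound 4 (0.22 log units; that floor lies within the scatter). Compound 4 is estimated at 15000 nM, within 4000 nM to 40000 nM.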

Compound 4, half-maximal inhibitory concentration: 14200 nM
Compound 4: the middle estimate sits 1.1-fold (0.02 log units) above what was measured; measured number inside the range.
By their numbers in this assay, from the lowest: compounds 3, 2 and 4 (each within the scatter of the next). At a limit, above all of these: compound 1.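

Putting 1-((1-methylethenyl)carbonyl)azetidin-3-yl in place of 2-((vinylcarbonyl)amino)ethyl on this oxygen gives an at least 1.7-fold lower number from compound 1 to compound 4 (0.24 log units; that floor lies within the scatter), so this floor alone does not establish a real gain. Compound 1 is only a limit, so the true size of this step cannot be read: the limit of > 25000 nM in this assay, at which 1 of the 4 values shown sits.

The compact group on the ring nitrogen of compound 4 also does not separate from either longer side chain, with a 1.6-fold higher number from compound 3 to compound 4 (0.19 log units; within the scatter) and a 1.2-fold higher number from compound 2 to compound 4 (0.08 log units; within the scatter).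

Still open, on these data alone, is whether a piperidine ring in place of the azetidine, or a free amine on that side chain, would move the number beyond the scatter.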